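From trifluoromethyl to trifluoromethoxy in an antiproliferative set

The source may report more compounds than this note shows. Statements on the series, on what has been measured and on what is new or still open speak of the compounds shown alone.

Compound 1 `CC(O)(CSc1cc(C(F)(F)F)cc(C(F)(F)F)c1)C(=O)Nc1ccc(C#N)cc1C(F)(F)F` gives 4650 nM 
Compound 2 `CC(O)(CSc1cccc(C(F)(F)F)c1)C(=O)Nc1cc(C(F)(F)F)cc(C(F)(F)F)c1` gives 9670 nM 

Among the measured compounds shown here, both numbers come from a functional assay on CWR22R cells (Homo sapiens) for antiproliferative activity, read by fluorescence and propidium iodide staining, with a stated time of 96 h (a higher number here means a weaker inhibitor, a lower number a stronger inhibitor), and are the only measurements so far. Compound 2 stands highest of the two, which makes it the weaker inhibitor here, and its gap to compound 1 lies beyond the usual scatter. For the measured compounds named here, no pair of measured compounds differs in just one place, so the data offer no measured step to lean on.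

Compound 3 `CC(O)(CSc1cccc(OC(F)(F)F)c1)C(=O)Nc1cc(C(F)(F)F)cc(C(F)(F)F)c1` has yet to be measured in this assay and departs from compound 2 in one place. Trifluoromethoxy stands in place of trifluoromethyl on an aromatic carbon trifluoromethoxy in place of trifluoromethyl on an aromatic carbon and so turns 3-(trifluoromethyl)phenyl into 3-(trifluoromethoxy)phenyl. Without a measured precedent for this change, the expected step of a 1.1-fold lower number from compound 2 to compound 3 (0.03 log units; within the scatter) is none beyond the scatter, in either direction. That expectation rests on compound 2 at 9670 nM as the only starting point. Compound 3 is expected at 9000 nM within an estimated range of 4000 nM to 20000 nM once measured.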

Compound 3, half-maximal inhibitory concentration: 6420 nM
Compound 3: the middle estimate sits 1.4-fold (0.15 log units) above what was measured; the range from low to high includes it.
By their numbers in this assay, from the lowest: compounds 1, 3 and 2 (each within the scatter of the next, the first and the last beyond it).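

The exchange of trifluoromethyl for trifluoromethoxy on an aromatic carbon, meta to a large group, gives the series its first measured step in this assay, and that step reads a 1.5-fold lower number from compound 2 to compound 3 (0.18 log units; within the scatter). At this position, with the rest of compound 2 held fixed, 3-(trifluoromethyl)phenyl and 3-(trifluoromethoxy)phenyl cannot be told apart by this read-out, even though the entering group has one more heavy atom and one hydrogen-bond acceptor by count. No measurement of any other kind is at hand that bears on this result.

As far as these compounds go, it remains open whether the same position would read alike with a group of another kind, such as an amine, a carboxylic acid or a plain methoxy group, in place of trifluoromethyl or trifluoromethoxy. From the compounds shown here alone, it is also open whether this exchange would give a similar step on the remainder of compound 1, which differs from compound 2 and compound 3 in more than one place and so offers no direct comparison with either.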